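A new group on the carbonyl carbon of compound 2

The source may hold more compounds than are shown below. What is called first, only, known or untested is meant among the compounds shown, and "the series" means these compounds.

In a functional assay on MCF7 cells (Homo sapiens) for inhibition, read by MTT assay (a higher number here means a weaker inhibitor, a lower number a stronger inhibitor), compound 1 `COc1cc2ncnc(Nc3ccc(NC(=O)c4cccc(C)c4)cc3)c2cc1OC` gives 13000 nM and compound 2 `COc1cc2ncnc(Nc3ccc(NC(=O)c4cccc(Cl)c4)cc3)c2cc1OC` gives 18000 nM. Going by the values given here, these two compounds stand level: the only measured step, chloro in place of methyl on an aromatic carbon, is a 1.4-fold higher number from compound 1 to compound 2 (0.14 log units; within the scatter). Compound 3 `COc1cc2ncnc(Nc3ccc(NC(=O)c4ccc(C(F)(F)F)cc4)cc3)c2cc1OC` keeps the shared core, but 4-(trifluoromethyl)phenyl replaces 3-chlorophenyl on a carbonyl carbon: 4-(trifluoromethyl)phenyl in place of 3-chlorophenyl on a carbonyl carbon. Among the compounds with values here, the measured step is the only guide here, and it is a limited one, since no tested compound carries the incoming group. With nothing pointing either way, no change beyond the scatter is expected in this assay, though the uncertainty is wide. The expected change is a 1.2-fold lower number from compound 2 to compound 3 (0.08 log units; within the scatter). Compound 3 is estimated at 15000 nM, with an expected range of 6000 nM to 40000 nM.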

Compound 3, half-maximal inhibitory concentration: > 100000 nM
Compound 3: only a limit was reported (the forecaster's own chance of this, stated with the estimate: 10%); middle value at least 6.6-fold (0.82 log units) from the limit.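

The value of compound 3 in this assay is a limit and not a number: the limit of > 100000 nM in this assay, at which 1 of the 3 values shown sits.

The step of an at least 5.5-fold higher number from compound 2 to compound 3 (0.74 log units; beyond the scatter) and the step of an at least 7.6-fold higher number from compound 1 to compound 3 (0.88 log units; beyond the scatter) both lie beyond the scatter, so the group on this carbonyl carbon can clearly shift the result. The earlier step of a 1.4-fold higher number from compound 1 to compound 2 (0.14 log units; within the scatter) had shown only that chloro and methyl on the aromatic ring could be exchanged without a change beyond the scatter.

Because 4-(trifluoromethyl)phenyl differs from the earlier groups in both its substituent and that substituent's place on the ring, these compounds cannot show which of the two drives the shift. They also leave open how the number would respond to an amine or a carboxylic acid on this phenyl ring.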